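A few compounds are considered here, and "the series" means these few. Any claim that something is new, unique, unknown or untested is made for them only; others in the source may bear on it.

Measured in a functional assay on LoVo cells (Homo sapiens) for cytotoxicity, read by MTT assay; a lower number here means a stronger inhibitor, a higher number a weaker inhibitor:
Compound 1 `Oc1ccc(CN(Cc2ccccc2)Cc2ccc(O)c3ncccc23)c2cccnc12` gives 91 nM
Compound 2 `Oc1ccc(CN(Cc2ccccc2C(F)(F)F)Cc2ccc(O)c3ncccc23)c2cccnc12` gives 93 nM

Compound 2 stands level with compound 1 in this assay and the two numbers lie within the usual scatter of each other. The next compound is compound 3 `Oc1ccc(CN(Cc2cccc(C(F)(F)F)c2)Cc2ccc(O)c3ncccc23)c2cccnc12` and the change leading to it is 3-(trifluoromethyl)phenyl in place of 2-(trifluoromethyl)phenyl on a saturated chain carbon bound to an amine nitrogen on a saturated chain carbon bound to an amine nitrogen. The two have the same atoms, joined differently. Within the data shown here, only one measured step bears on this: trifluoromethyl in place of hydrogen on an aromatic carbon gave a 1.0-fold higher number from compound 1 to compound 2 (0.01 log units; within the scatter) and stayed within the scatter. Among the measured compounds shown here, no measured pair compares two places for the group, so this guide is indirect. With no direction favoured, the estimated step is a 1.0-fold lower number from compound 2 to compound 3 (0.00 log units; within the scatter) and nothing beyond the scatter is expected. Compound 3 is expected at 92 nM as an estimate (40 nM to 200 nM).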

Compound 3, half-maximal inhibitory concentration: 94 nM
For compound 3 the middle estimate is 1.0-fold (0.01 log units) below the measured one, and the stated range covers the measured number.
By their numbers in this assay, from the lowest: compounds 1, 2 and 3 (each within the scatter of the next).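

In this assay, exchanging 2-(trifluoromethyl)phenyl for 3-(trifluoromethyl)phenyl on a saturated chain carbon bound to an amine nitrogen gives a 1.0-fold higher number from compound 2 to compound 3 (0.00 log units; within the scatter), so these two placements of the trifluoromethyl group cannot be told apart here. Setting the 3-(trifluoromethyl)phenyl group against plain phenyl gives a 1.0-fold higher number from compound 1 to compound 3 (0.01 log units; within the scatter), so this placement, like the earlier one, does not separate from hydrogen. Nothing available here offers an explanation for this flat result.

On these data alone, it remains open whether this position is as undemanding towards groups of another kind. A hydroxyl, an amine or a carboxylic acid on this phenyl ring, or a longer chain in place of the benzyl, might move the number beyond the scatter, or might leave it level with compound 1.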